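A few compounds are considered here, and "the series" means these few. Any claim that something is new, unique, unknown or untested is made for them only; others in the source may bear on it.

Compound 1 `CO[C@]1(C)O[C@H]2[C@H](O)C=C(COC(C)=O)C(=O)[C@@H]2O[C@@]1(C)OC`: > 100000 nM
Compound 2 `CO[C@]1(C)O[C@H]2[C@@H](O)C=C(COC(C)=O)C(=O)[C@@H]2O[C@@]1(C)OC`: "not determined" (no result reported)

In an assay on isolated protein for inhibition of glutathione S-transferase A2 (Homo sapiens), read by spectrophotometry, with a stated time of 3 min (a lower number here means a stronger inhibitor, a higher number a weaker inhibitor), compound 1 gives only a limit, > 100000 nM. Compound 2 has no result in this assay , so it stands without a number of its own; what can be said of it rests on compound 1, which differs from it only through (the fact that compounds 1 and 2 differ only in the configuration as drawn). Compound 3 `CO[C@]1(C)O[C@H]2[C@@H](OC/C=C/c3ccccc3)C=C(COC(C)=O)C(=O)[C@@H]2O[C@@]1(C)OC` is reached from compound 2 by 3-phenylprop-2-en-1-yl in place of hydrogen on an oxygen on a saturated carbon. Among the compounds with values here, no step between two measured compounds exists here, so the size of this move cannot be read from the numbers. Since compound 1 sits at the limit of > 100000 nM in this assay, at which 1 of the 2 values shown sits, a shift toward stronger inhibition in this assay is expected rather than none at all, though its extent remains uncertain. For compound 3 the estimated value is 60000 nM, with a range from 10000 nM to 300000 nM.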

Compound 3, half-maximal inhibitory concentration: 94200 nM
Compound 3: middle estimate off by 1.6-fold (0.20 log units), on the low side; the measured number falls inside the stated range.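

Within the data shown here, compound 3 gives 94200 nM in this assay, yet no step from compound 2 or compound 1 to compound 3 can be read from this value. The compounds shown leave open how far the change from hydroxy to (3-phenylprop-2-en-1-yl)oxy shifts inhibition, and whether the configuration as drawn matters.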